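Adding a Nitrile to the Phenoxy Ring: Expected Cytotoxicity

A few compounds are considered here, and "the series" means these few. Any claim that something is new, unique, unknown or untested is made for them only; others in the source may bear on it.

Measured compounds:
Compound 1 `O=C(Nc1cc(-c2ccccn2)n[nH]1)N1CCC(Oc2ccccc2)CC1` gives > 40000 nM
Compound 2 `O=C(Nc1[nH]nc(-c2ccccn2)c1C1CC1)c1c(Cl)cccc1Cl` gives > 64000 nM

Both values come from an ADME assay on cells (Peritoneal macrophage cell, Mus musculus) for cytotoxicity, read by fluorescence and resazurin assay, with a stated time of 3 days; on this read-out higher numbers stand for lower toxicity in this test and lower numbers for higher toxicity in this test. For compound 1 the value is a limit of the test, not a number, as the limit of > 40000 nM in this assay, at which 1 of the 2 values shown sits, shows. For compound 2 the value is likewise a limit, as the limit of > 64000 nM in this assay, at which 1 of the 2 values shown sits, shows. Since both sit at a limit, compound 1 cannot be placed above or below compound 2; all that can be said is that neither showed measurable toxicity within the tested range.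

Compound 3 `N#Cc1ccc(OC2CCN(C(=O)Nc3cc(-c4ccccn4)n[nH]3)CC2)cc1` is not yet measured. It differs from compound 1 in one place: cyano in place of hydrogen on an aromatic carbon, so the phenoxy becomes 4-cyanophenoxy. For the measured compounds named here, no measured pair shows the effect of this change. In this assay the step of a number no higher from compound 1 to compound 3 (the limit leaves the size open) is expected to be none beyond the scatter, with compound 3 most likely reported as a limit again. Compound 3 is therefore estimated at 40000 nM, within a range from 20000 nM to 80000 nM.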

Compound 3, half-maximal cytotoxic concentration: > 64000 nM
Compound 3: only a limit was reported (the forecaster's own chance of this, stated with the estimate: 85%); middle value at least 1.6-fold (0.20 log units) from the limit.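

For the compounds shown here, compound 1 and compound 3 are each reported only as a limit of the test, and no step between them can be read. The compounds shown leave open where their true values lie and whether the 4-cyanophenoxy group changes the result in this assay at all.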